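This account rests on a few compounds, and the source may have more. Where it says the series, first, only, none or still open, it means among the compounds named here.

Measured in a functional assay on HL-60 cells (Homo sapiens) for inhibition, read by CCK-8 assay, with a stated time of 48 h; on this read-out higher numbers stand for weaker inhibition and lower numbers for stronger inhibition:
Compound 1 `O=[N+]([O-])c1cccc(NC(=S)NCCNS(=O)(=O)c2ccc(-c3ccccc3OCc3ccccc3)s2)c1`: > 50000 nM
Compound 2 `Cc1cc(C)cc(NC(=O)NCCNS(=O)(=O)c2ccc(-c3ccccc3OCc3ccccc3)s2)c1`: 2200 nM

The entry for compound 1 is a limit and not a number. Among the measured compounds shown here, compound 2 therefore holds the only true number, 2200 nM.

Not yet measured is compound 3 `O=S(=O)(NCCNC(=S)Nc1ccc(Cl)cc1)c1ccc(-c2ccccc2OCc2ccccc2)s1`. Relative to compound 2, the change is a group of 10 heavy atoms (7 carbon, 1 nitrogen, 1 sulfur, 1 chlorine; one six-membered aromatic ring of carbon only) in place of a group of 11 heavy atoms (9 carbon, 1 nitrogen, 1 oxygen; one six-membered aromatic ring of carbon only), on an amine nitrogen. The entering group carries sulfur, as the group in compound 1 does.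

For the measured compounds named here, the only measured step bearing on this is an at least 22-fold lower number from compound 1 to compound 2 (1.35 log units; beyond the scatter). It is large, but it starts from a limit and involves a different aromatic substitution, so it suggests a direction and gives no firm size. A moderately higher number is expected in this assay, with a real chance of reaching the limit.

The expected change is a 4.1-fold higher number from compound 2 to compound 3 (0.61 log units; beyond the scatter). The estimated value for compound 3 is 9000 nM, with an expected range of 2500 nM to 40000 nM.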

Compound 3, half-maximal inhibitory concentration: > 50000 nM
Compound 3 gave a limit, no number (the forecaster's own chance of this, stated with the estimate: 25%); middle value at least 5.5-fold (0.74 log units) away from the limit.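

In this assay, compound 3 ends at a limit and not at a number, as compound 1 does. The change gives an at least 22-fold higher number from compound 2 to compound 3 (1.35 log units; beyond the scatter), so the loss seen with the 3-nitrophenyl group in compound 1 also appears with a 4-chlorophenyl group when sulfur is present in the group on the amine nitrogen. The two sulfur-bearing compounds cannot be ranked, and the step between them cannot be read: the limit of > 50000 nM in this assay, at which 2 of the 3 values shown sit.

Compound 3 differs from compound 2 in both the sulfur-for-oxygen exchange and the ring substituents, so the shown compounds do not separate these two changes. Open, going by these compounds, are the 3,5-dimethylphenyl ring paired with sulfur, the 4-chlorophenyl ring paired with the carbonyl oxygen, and a phenyl ring carrying a carboxylic acid or an amine.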